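Urea in place of amide on the shared core

The source may report more compounds than this note shows. Statements on the series, on what has been measured and on what is new or still open speak of the compounds shown alone.

Compound 1 `O=C(Nc1cccc(-n2cc(-c3ccncc3)c(-c3ccc(Cl)c(O)c3)n2)c1)Nc1cccc(C(F)(F)F)c1`: 1060 nM
Compound 2 `COc1cc(-c2nn(-c3cccc(NC(=O)c4cccc(C(F)(F)F)c4)c3)cc2-c2ccncc2)ccc1Cl`: 1200 nM
Compound 3 `O=C(Nc1cccc(-n2cc(-c3ccncc3)c(-c3ccc(Cl)c(O)c3)n2)c1)Nc1ccc(Cl)c(Cl)c1`: 1050 nM

Of the compounds shown here, three have been measured in a functional assay on OVCAR-3 cells (Homo sapiens) for inhibition, read by sulforhodamine B assay, with a stated time of 48 h; a higher number here means a weaker inhibitor, a lower number a stronger inhibitor. Compound 2 gives the highest of the three numbers, yet its distance to compound 1 and to compound 3 lies within the scatter, so the three values are indistinguishable on this evidence. Among the measured compounds shown here, the only single-point step among the measured compounds is a 1.0-fold lower number from compound 1 to compound 3 (0.00 log units; within the scatter), which changes the aryl group on the amide-type nitrogen and leaves the number unchanged.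

Compound 4 `COc1cc(-c2nn(-c3cccc(NC(=O)Nc4cccc(C(F)(F)F)c4)c3)cc2-c2ccncc2)ccc1Cl` is the next compound to be measured. It differs from compound 2 in one place: (3-(trifluoromethyl)phenyl)amino in place of 3-(trifluoromethyl)phenyl on a carbonyl carbon. This amide-to-urea change is not covered by any measured step. The closest reference is compound 1, a urea bearing the same 3-(trifluoromethyl)phenyl group, whose value sits within the scatter of compound 2. For the measured compounds named here, with no measured step pointing either way, the estimated step of a 1.1-fold lower number from compound 2 to compound 4 (0.04 log units; within the scatter) is expected to stay within the scatter. Compound 4 is therefore estimated at 1100 nM, with a range from 500 nM to 2500 nM.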

Compound 4, half-maximal inhibitory concentration: 580 nM
The estimate for compound 4 lay 1.9-fold (0.28 log units) above the measured number; measured number inside the range.
By their numbers in this assay, from the lowest: compounds 4, 3, 1 and 2 (each within the scatter of the next, the first and the last beyond it).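

In this assay, putting (3-(trifluoromethyl)phenyl)amino in place of 3-(trifluoromethyl)phenyl on a carbonyl carbon, which turns the amide of compound 2 into the urea of compound 4, gives a 2.1-fold lower number from compound 2 to compound 4 (0.32 log units; beyond the scatter), a modest step and the first one in this small set to pass the scatter. By count, the entering group brings one nitrogen and one hydrogen-bond donor, but nothing available here accounts for the shift in the number. Among the ureas, methyl in place of hydrogen on an oxygen on an aromatic ring gives a 1.8-fold lower number from compound 1 to compound 4 (0.26 log units; within the scatter), so this change does not separate the two compounds, and the oxygen substituent cannot be said to matter on this evidence.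

As far as these compounds go, the amide-to-urea step rests on a single pair, so it remains open whether it would recur with a hydroxy group on the aromatic ring or with 3,4-dichlorophenyl on the amide-type nitrogen. The compounds shown also leave open how a carbamate or a thiourea would compare with the urea at this position.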